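Lengthening the side chain of compound 1

This account rests on a few compounds, and the source may have more. Where it says the series, first, only, none or still open, it means among the compounds named here.

Among the measured compounds shown here, in an ADME assay on L6 cells (Rattus norvegicus) for cytotoxicity (on this read-out lower numbers stand for stronger inhibition and higher numbers for weaker inhibition), compound 1 (`O=C(CN1CCCCC1)OC1CC2(N3CCCC3)CC(c3ccccc3)C1C(c1ccccc1)C2`) gives 14200 nM as its only number. Compound 2 (`O=C(CN1CCCCC1)OC1CC2(N3CCCCC3)CC(c3ccccc3)C1C(c1ccccc1)C2`) gives 60400 nM; > 184000 nM (2 entries) in its entries. The entry with the sign is a limit of the assay, not a number. Compound 3 (`O=C(CCN1CCCCC1)OC1CC2(N3CCCC3)CC(c3ccccc3)C1C(c1ccccc1)C2`) has (piperidin-1-yl)methyl in place of piperidin-1-yl on a saturated chain carbon bound to a carbonyl carbon. For the measured compounds named here, no measured pair shows this kind of change, so in this assay only a small shift of no firm direction is expected, none beyond the usual scatter (a 1.1-fold higher number from compound 1 to compound 3 (0.02 log units; within the scatter)). The estimated value for compound 3 is 15000 nM (expected range 5000 nM to 45000 nM).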

Compound 3, half-maximal inhibitory concentration: 17800 nM
Compound 3: the middle estimate sits 1.2-fold (0.07 log units) below what was measured; measured number inside the range.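

In this assay, putting (piperidin-1-yl)methyl in place of piperidin-1-yl on a saturated chain carbon bound to a carbonyl carbon gives a 1.3-fold higher number from compound 1 to compound 3 (0.10 log units; within the scatter). Among the compounds shown here, the two earlier compounds differ from each other elsewhere, so only this step shows that this lengthening of the side chain does not separate the two compounds on this read-out. No other measurement shown bears on this step. Still open, from the compounds shown here alone, is whether a longer chain, such as 3-(piperidin-1-yl)propyl, or morpholine in place of the piperidine ring would also stay within the scatter.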